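The source may report more compounds than this note shows. Statements on the series, on what has been measured and on what is new or still open speak of the compounds shown alone.

Measured so far in a functional assay on the whole organism for activation, with Mus musculus as the target; a higher number here means that more compound is needed for the effect, a lower number that less compound is needed:
compound 1, `CCCCCNc1nc(N)c2nc(O)n(Cc3ccccc3)c2n1`: 0.3 mg/kg
compound 2, `Nc1ncnc2c1nc(S)n2Cc1ccccc1`: > 30 mg/kg

Within the data shown here, compound 1 is the only compound of the pair with a numerical minimum effective dose, and in this assay compound 1 gives 0.3 mg/kg. For compound 2 this assay reports only a limit, > 30 mg/kg, so the reading for compound 2 is the limit itself and not a number; this is the situation described by the limit of > 30 mg/kg in this assay, at which 1 of the 2 values shown sits. Among the measured compounds shown here, no step between two measured compounds is available here, and compound 2 carries a different core substitution, so nothing measured bears directly on the change considered next.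

Compound 3, `CCCC[S+]([O-])c1nc(N)c2nc(O)n(Cc3ccccc3)c2n1`, is not yet measured. Its difference from compound 1 is a group of 6 heavy atoms (4 carbon, 1 oxygen, 1 sulfur; no ring) in place of a group of 6 heavy atoms (5 carbon, 1 nitrogen; no ring), on an aromatic carbon — the pentylamino on compound 1 replaced on the same aromatic carbon by the four-carbon chain carrying oxygen and sulfur, a group without a hydrogen-bond donor. For the measured compounds named here, with no measured step of this kind, the expected step is a modest loss, a 3.3-fold higher number from compound 1 to compound 3 (0.52 log units; beyond the scatter), somewhat beyond the usual scatter but not large. The minimum effective dose of compound 3 in this assay is estimated at 1 mg/kg, with a likely range from 0.3 mg/kg to 10 mg/kg.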

Compound 3, minimum effective dose: 1 mg/kg
The estimate for compound 3 equals the measured number at the digits printed; the measured number falls inside the stated range.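

Among these compounds, this is the first direct comparison at the aromatic carbon between two ring nitrogen atoms: in this assay, the step of a 3.3-fold higher number from compound 1 to compound 3 (0.52 log units; beyond the scatter) is modest but lies beyond the scatter. The entering group has no hydrogen-bond donor, yet compound 3 still gives a numerical minimum effective dose of 1 mg/kg, so a hydrogen-bond donor on this carbon is not a requirement for an effect in whole animals, and the pentylamino group can be replaced here without the activity being lost. Among the compounds shown here, nothing measured so far gives a reason for the size of this step.

On these data alone, the step changes the atom attached to the ring and the chain together, so it remains open whether the higher number goes with the group of sulfur and oxygen or with the shorter four-carbon chain. A butylamino group or a butoxy group on the same carbon would separate these two changes, and a longer chain on the sulfur and oxygen group would show whether the pentylamino level of compound 1 can be recovered.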